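The source may hold more compounds than are shown below. What is called first, only, known or untested is meant among the compounds shown, and "the series" means these compounds.

Three compounds sharing one core were tested in an assay on cells for displacement of a labelled ligand from prostaglandin E2 receptor EP4 subtype (Homo sapiens), read by scintillation counting, tested at 10 uM; on this read-out higher numbers stand for more inhibition at the one concentration tested (going by the name of the read-out) and lower numbers for less inhibition. Compound 1, `Cc1oc(C(=O)O)cc1COc1ccc(C(C)(C)c2ccccc2)cc1`, gives 23% in this assay. Compound 2, `Cc1oc(C(=O)O)cc1COc1ccc(Oc2ccccc2)cc1`, gives 7%. Compound 3, `CCOC(=O)c1cc(COc2ccc(-c3ccccc3)cc2)c(C)o1`, carries an ethoxycarbonyl group where the other two carry a carboxylic acid, and in this assay compound 3 gives 15%. Its number sits between those of compound 1 and compound 2, and the gap to each of them is within the usual scatter of repeated measurements, so the three results cannot be told apart with confidence.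

Compound 4, `Cc1oc(CC(=O)O)cc1COc1ccc(-c2ccccc2)cc1`, has not yet been measured. Against compound 3 the change is this: carboxymethyl in place of ethoxycarbonyl on an aromatic carbon. For the measured compounds named here, no pair of measured compounds shows this exact change, so its effect is unknown. Because compound 1 with its acid gives 23% and compound 3 with its ester gives 15%, the step from compound 3 to compound 4 is expected to be small, no change at the digits printed from compound 3 to compound 4 (within the scatter), with no clear direction beyond the scatter. Compound 4 is therefore estimated to give about 15%, between 2% and 35%.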

Compound 4, a percentage reported as inhibition, at one concentration (the size of the read-out at that concentration, not a potency): 61%
The estimate for compound 4 lay 46 percentage points below the measured number; measured number above the stated range.
By their numbers in this assay, from the lowest: compounds 2, 3 and 1 (each within the scatter of the next, the first and the last beyond it); then compound 4.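

In this assay, replacing ethoxycarbonyl with carboxymethyl on the aromatic carbon next to the ring oxygen gives a number 46 percentage points higher from compound 3 to compound 4 (beyond the scatter). For the compounds shown here, this is the first readable step between compounds that differ in one place, and it shows that the group at this position can move the number far beyond the scatter. The swap changes two things at once, however: the ester gives way to an acid that carries a hydrogen-bond donor, and the link between the carbonyl and the ring changes too.

No measurement here explains the rise. From the compounds shown here alone, it remains open which of the two changes matters, and the ethyl ester of the carboxymethyl group, its amide or a longer carboxyethyl chain at this position would help separate them.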